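Hydroxy in Place of Dimethylcarbamoyl on a Saturated Ring Carbon

The compounds below may be only part of what the source reports. "The series", "measured", "known", "first", "only" and "open" are said of these compounds alone.

In a functional assay on HEK293 cells for agonist activity at Glucose-dependent insulinotropic receptor (Homo sapiens), read by reporter gene assay and cAMP accumulation, with a stated time of 6 h (a lower number here means that less compound is needed, a higher number that more compound is needed for the effect), compound 1 `CN(C)C(=O)C1CCN(c2nc(-c3cc(F)c(Cl)cc3F)nc3c2CS(=O)(=O)C3)CC1` gives 350 nM and stands highest of the three numbers measured. Compound 2 `O=S1(=O)Cc2nc(-c3cc(F)c(Cl)cc3F)nc(N3CCC(CO)CC3)c2C1` gives 3.9 nM in this assay and compound 3 `NC(=O)C1CCN(c2nc(-c3cc(F)c(Cl)cc3F)nc3c2CS(=O)(=O)C3)CC1` gives 21 nM in this assay as well. Compound 4 `O=S1(=O)Cc2nc(-c3cc(F)c(Cl)cc3F)nc(N3CCC(O)CC3)c2C1` differs from compound 1 by hydroxy in place of dimethylcarbamoyl on a saturated ring carbon on the same core. Two measured steps start from compound 1 and bear on this change: a 90-fold lower number from compound 1 to compound 2 (1.95 log units; beyond the scatter) and a 17-fold lower number from compound 1 to compound 3 (1.22 log units; beyond the scatter) both move the number down when dimethylcarbamoyl is exchanged for hydroxymethyl or carbamoyl. Between those two, a 5.4-fold higher number from compound 2 to compound 3 (0.73 log units; beyond the scatter) shows hydroxymethyl giving the lower number. A large downward step is therefore expected, a 44-fold lower number from compound 1 to compound 4 (1.64 log units; beyond the scatter) in this assay as the estimate. Compound 4 is expected to give 8 nM in this assay with a range from 2 nM to 40 nM around it.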

Compound 4, effective concentration (reported as EC, without a stated level of effect): 14 nM
Compound 4: the middle estimate sits 1.8-fold (0.24 log units) below what was measured, within the range that was stated.
By their numbers in this assay, from the lowest: compound 2; then compounds 4 and 3 (each within the scatter of the next); then compound 1.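

In this assay, among the compounds shown here, the single hydroxy of compound 4 is enough to bring the number down, with a 25-fold lower number from compound 1 to compound 4 (1.40 log units; beyond the scatter), so the carbonyl of the dimethylcarbamoyl group is not required at this ring carbon. Hydroxy and carbamoyl cannot be told apart, with a 1.5-fold lower number from compound 3 to compound 4 (0.18 log units; within the scatter), yet hydroxymethyl still holds the lowest number, with a 3.6-fold higher number from compound 2 to compound 4 (0.56 log units; beyond the scatter). Nothing measured here explains these differences. On these data alone, whether an amine, a carboxylic acid or a longer hydroxyalkyl chain on this ring carbon would match compound 2 remains open.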